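From hydroxy to ethyl on the chain of compound 3

This account rests on a few compounds, and the source may have more. Where it says the series, first, only, none or still open, it means among the compounds named here.

Three measured compounds share one core and differ in the chain on an aromatic nitrogen. In a functional assay on HeLa cells (Homo sapiens) for antiproliferative activity, read by MTT assay, with a stated time of 48 h (a higher number here means a weaker inhibitor, a lower number a stronger inhibitor), compound 1 `Cn1c(N)c(-c2nc3ccccc3[nH]2)c2nc(C#N)c(C#N)nc21` gives > 50000 nM, which is a limit of the assay and not a number. Compound 3 `N#Cc1nc2c(-c3nc4ccccc4[nH]3)c(N)n(CCO)c2nc1C#N` gives > 50000 nM, again only a limit. Compound 2 `CCN(CC)CCn1c(N)c(-c2nc3ccccc3[nH]2)c2nc(C#N)c(C#N)nc21` gives a true number, 11600 nM. Compound 3 therefore stands at the limit of > 50000 nM in this assay, at which 2 of the 3 values shown sit.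

Compound 4 `CCCCn1c(N)c(-c2nc3ccccc3[nH]2)c2nc(C#N)c(C#N)nc21` alters compound 3 in one place: ethyl in place of hydroxy on a saturated chain carbon, two bonds along the chain from an aromatic nitrogen. This puts ethyl in place of hydroxy on a saturated chain carbon, two bonds along the chain from an aromatic nitrogen, turning 2-hydroxyethyl into butyl.

Among the compounds with values here, two measured steps bear on this chain. Putting (diethylamino)methyl in place of hydrogen gave an at least 4.3-fold lower number from compound 1 to compound 2 (0.63 log units; beyond the scatter). Putting hydroxy in place of diethylamino gave an at least 4.3-fold higher number from compound 2 to compound 3 (0.63 log units; beyond the scatter). Both show that the end of this chain can move the number, but neither involves ethyl, so only a modest move toward a lower number is expected in this assay, and another limit would be no surprise. The expected change is an at least 1.6-fold lower number from compound 3 to compound 4 (0.22 log units; that floor lies within the scatter). For compound 4 the estimate is 30000 nM, with an expected range from 12000 nM to 60000 nM.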

Compound 4, half-maximal inhibitory concentration: > 50000 nM
Compound 4 was reported as a limit (the forecaster's own chance of this, stated with the estimate: 45%); middle value at least 1.6-fold (0.22 log units) away from the limit.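

In this assay compound 4 gives > 50000 nM, which is a limit of the assay and not a number. Within the data shown here, the one step that can be read here puts ethyl in place of diethylamino on a saturated chain carbon, two bonds along the chain from an aromatic nitrogen, and it gives an at least 4.3-fold higher number from compound 2 to compound 4 (0.63 log units; beyond the scatter), so the butyl chain does not keep the measurable activity of compound 2, just as the 2-hydroxyethyl chain of compound 3 did not. The steps that link compound 4 to compound 1 and to compound 3 cannot be read, with a limit at both ends, and among these compounds only the chain carrying diethylamino gives a true number, with no compound going against this, while the rest share one ceiling: the limit of > 50000 nM in this assay, at which 3 of the 4 values shown sit.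

Going by these compounds, whether a different amine, such as dimethylamino or a pyrrolidine ring, or the same diethylamino on a longer chain, would also give a true number stays open. So does the effect of a carboxylic acid on this chain, and compound 1, compound 3 and compound 4 cannot be put in any order, as all three sit at a limit.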